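Hydrazide series: chain branch replaced by cyclohexyl

The source may report more compounds than this note shows. Statements on the series, on what has been measured and on what is new or still open speak of the compounds shown alone.

Two hydrazides of the shared core have been measured. Compound 1 `Cc1ccccc1NNC(=O)CCC(C)C` is tested in an in vitro functional assay on 1321-N1 cells for antagonist activity at P2X purinoceptor 7 (Rattus norvegicus), read by FLIPR and calcium flux (on this read-out higher numbers stand for weaker inhibition and lower numbers for stronger inhibition), where compound 1 gives 339 nM. Compound 2 `Cc1ccccc1NNC(=O)C1CCCCC1` in this assay gives 245 nM. Of the two numbers, that of compound 1 is the larger, but the gap to compound 2 sits within the usual scatter of repeated measurements, so the two compounds cannot be ranked against each other on this read-out.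

Compound 3 `Cc1ccccc1NNC(=O)CC1CCCCC1` is not yet measured. Relative to compound 1 the change is cyclohexyl in place of isobutyl on a saturated chain carbon bound to a carbonyl carbon. For the measured compounds named here, no measured pair reports this exact change, so the size of the step can only be expected, not read off. Since compound 1 with its value of 339 nM and compound 2 with its value of 245 nM lie within the scatter of each other, the expected step in this assay a 1.3-fold lower number from compound 1 to compound 3 (0.12 log units; within the scatter) is small, and its direction is uncertain; a shift beyond the scatter is not expected. For compound 3 the expected value in this assay is 260 nM, with a range from 100 nM to 700 nM.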

Compound 3, half-maximal inhibitory concentration: 151 nM
Estimate against measurement, compound 3: 1.7-fold (0.24 log units) above; measured number inside the range.
By their numbers in this assay, from the lowest: compounds 3, 2 and 1 (each within the scatter of the next, the first and the last beyond it).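

In this assay, for the compounds shown here, cyclohexyl in place of isobutyl on a saturated chain carbon bound to a carbonyl carbon gives a 2.2-fold lower number from compound 1 to compound 3 (0.35 log units; beyond the scatter) and is the first single change to clear the scatter, though the step remains modest. This position therefore accepts a larger group carrying one six-membered non-aromatic ring of carbon only, with stronger inhibition rather than a loss. Neither group carries a hydrogen-bond donor or acceptor, so the gain comes from a change made in carbon alone, and no measurement at hand accounts for it.

Going by these compounds, whether the gain belongs to the ring itself or simply to the larger count of carbon stays open, since a longer open chain of comparable size, such as n-hexyl, would be needed to separate the two, and a phenyl ring in place of cyclohexyl would test whether the ring must be saturated. A basic amine or a carboxylic acid on the cyclohexyl ring also remains untested in the compounds shown, which leaves the tolerance of this position for hydrogen-bonding or charged groups unknown.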